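The compounds below may be only part of what the source reports. "The series", "measured", "known", "first", "only" and "open" are said of these compounds alone.

Measured compounds in this series:

compound 1 `Cc1c(C(=O)N/N=C\c2cccc(O)c2)oc2cccc(O)c12` — 17600 nM
compound 2 `Cc1c(C(=O)N/N=C\c2cc(Cl)cc(Cl)c2O)oc2cccc(O)c12` — 9590 nM
compound 3 `Cc1c(C(=O)N/N=C\c2ccccc2O)oc2cccc(O)c12` — 8350 nM

In a functional assay on PC-3 cells (Homo sapiens) for inhibition (on this read-out lower numbers stand for stronger inhibition and higher numbers for weaker inhibition), compound 3 gives 8350 nM, the lowest of the three numbers recorded. Compound 2 lies within the scatter of it, so no order between the two can be claimed. Compound 1 is further off: a 2.1-fold lower number from compound 1 to compound 3 (0.32 log units; beyond the scatter), a modest step.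

Compound 4 `COc1ccccc1/C=N\NC(=O)c1oc2cccc(O)c2c1C` is next, differing from compound 3 by methyl in place of hydrogen on an oxygen on an aromatic ring — hydroxy to methoxy, so 2-hydroxyphenyl to 2-methoxyphenyl. Among the compounds with values here, the single one-place step measured so far, a 2.1-fold lower number from compound 1 to compound 3 (0.32 log units; beyond the scatter), concerns where the hydroxy group sits on the phenyl ring, not its capping with methyl. Within the data shown here, no measured pair shows methoxy in place of hydroxy anywhere, so the change has no direct precedent here and the steps seen give no direction to lean on.

The working expectation is therefore a step near the scatter, with a wide range: the step from compound 3 is estimated as a 1.3-fold higher number from compound 3 to compound 4 (0.12 log units; within the scatter). For compound 4 the estimated value in this assay is 11000 nM, within 4000 nM to 35000 nM.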

Compound 4, half-maximal inhibitory concentration: 32700 nM
The estimate for compound 4 lay 3.0-fold (0.47 log units) below the measured number; low and high end bracket the measured number.
By their numbers in this assay, from the lowest: compounds 3, 2, 1 and 4 (each within the scatter of the next, the first and the last beyond it).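

Methyl in place of hydrogen on this oxygen is the first change in the series that caps the hydroxy group instead of moving it, and in this assay it weakens inhibition (a 3.9-fold higher number from compound 3 to compound 4 (0.59 log units; beyond the scatter)). Against 3-hydroxyphenyl, 2-methoxyphenyl gives a step within the scatter (a 1.9-fold higher number from compound 1 to compound 4 (0.27 log units; within the scatter)), so no order can be claimed for that pair, and the advantage of 2-hydroxyphenyl over 3-hydroxyphenyl is not kept once this oxygen carries methyl. No measurement shown here offers an explanation for the step.

From the compounds shown here alone, whether the hydrogen on this oxygen or the size of what replaces it governs the step stays open; an amine in place of the hydroxy, or ethoxy in place of methoxy, would help tell these apart. Going by these compounds, whether capping the hydroxy on the shared core has a similar effect also remains open.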